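From Two Rings to an Open Chain

This account rests on a few compounds, and the source may have more. Where it says the series, first, only, none or still open, it means among the compounds named here.

In an ADME assay on RD cells (Homo sapiens) for cytotoxicity, read by neutral red uptake, with a stated time of 3 days (a higher number here means that more compound is tolerated, a lower number that less compound is tolerated), compound 2 (`O=C(NC1CN2CCC1CC2)c1cc(-c2ccccc2)nc2ccccc12`) gives 46500 nM and so holds the lower of the two exact numbers available. Compound 3 (`CC(C)Oc1cc(C(=O)NCCCN(C)C)c2ccccc2n1`) gives the higher one (122000 nM). Compound 1 (`CN(C)c1ccc(NC(=O)c2cc(-c3ccccc3)nc3ccccc23)cc1`) reaches only a limit of the assay (> 350000 nM).

Compound 4 (`CCN(CC)CCCNC(=O)c1cc(-c2ccccc2)nc2ccccc12`) has not yet been measured. On the amide-type nitrogen, the ring-bearing group of compound 2 gives way to 3-(diethylamino)propyl (a group of 8 heavy atoms (7 carbon, 1 nitrogen; no ring) in place of a group of 8 heavy atoms (7 carbon, 1 nitrogen; 2 six-membered non-aromatic rings with 1 hetero atom each), on an amide-type nitrogen). The new group has no ring, but the counted heavy atoms stay the same.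

Within the data shown here, only one measured step changes the group at this place (an at least 7.5-fold lower number from compound 1 to compound 2 (0.87 log units; beyond the scatter)). It lies beyond the scatter, but it removes an aromatic ring group, which the step to compound 4 does not, so it offers little guidance on size. Compound 3 is a looser guide, since it also carries an open chain on its amide-type nitrogen, although its core differs, and its value (122000 nM) stays in the same broad region as that of compound 2.

No change beyond the scatter is therefore expected in this assay. The expected change is small (a 1.2-fold higher number from compound 2 to compound 4 (0.07 log units; within the scatter)). The estimate for compound 4 is 55000 nM with an expected range from 20000 nM to 150000 nM in this assay.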

Compound 4, half-maximal cytotoxic concentration: 45400 nM
Estimate against measurement, compound 4: 1.2-fold (0.08 log units) above, and the stated range covers the measured number.
By their numbers in this assay, from the lowest: compounds 4 and 2 (each within the scatter of the next); then compound 3. At a limit, above all of these: compound 1.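

In this assay, putting the open 3-(diethylamino)propyl chain in place of the two-ring group of compound 2, with the same count of heavy atoms on the amide-type nitrogen, gives a 1.0-fold lower number from compound 2 to compound 4 (0.01 log units; within the scatter), so on this core the assay does not separate the group with rings from the group without them. The aromatic 4-(dimethylamino)phenyl group on the same nitrogen stands apart from the open chain, with a step that lies beyond the scatter: an at least 7.7-fold lower number from compound 1 to compound 4 (0.88 log units; beyond the scatter) places the open chain with the two-ring group of compound 2, well away from compound 1. The true size of that step stays unknown because compound 1 sits at a limit of the assay and not at a number: the limit of > 350000 nM in this assay, at which 1 of the 4 values shown sits.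

Going by these compounds, it remains open whether a shorter chain such as 2-(diethylamino)ethyl, or a chain with no amine at all such as plain butyl, would keep the number in the same region. An unsubstituted phenyl group at this nitrogen would help show whether the aromatic ring itself or its dimethylamino group sets compound 1 apart.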